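The source may report more compounds than this note shows. Statements on the series, on what has been measured and on what is new or still open speak of the compounds shown alone.

Three compounds sharing one core differ only in how two methoxy groups are arranged on the six-membered aromatic ring of carbon only: compound 1 `COc1ccc(CNc2ncnc3c2ncn3C2CCCCO2)c(OC)c1`, compound 2 `COc1ccc(OC)c(CNc2ncnc3c2ncn3C2CCCCO2)c1` and compound 3 `COc1ccc(CNc2ncnc3c2ncn3C2CCCCO2)cc1OC`. In an ADME assay on K562 cells (Homo sapiens) for cytotoxicity, with a stated time of 72 h (on this read-out higher numbers stand for weaker inhibition and lower numbers for stronger inhibition), compound 3 reads > 100000 nM, which is a limit of the assay and not a number. Compound 1 reads > 25000 nM, which is also a limit. Among the compounds with values here, compound 2 gives the only true number of the set, 16500 nM. Compound 3 therefore stands at the highest limit shown, with no measured potency of its own.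

Compound 4 `COc1cc(OC)c(OC)cc1CNc1ncnc2c1ncn2C1CCCCO1` follows from compound 3 by one change, methoxy in place of hydrogen on an aromatic carbon. Its ring then carries the methoxy groups of all three measured compounds. Within the data shown here, no measured step shows what such an addition does, so the expectation is a loose one. It leans on compound 2, which holds two of these groups and reads 16500 nM. Compound 3 holds two of them as well and gave no number, so a limit could be reported again. A moderate move toward stronger inhibition in this assay is expected, estimated as an at least 2.8-fold lower number from compound 3 to compound 4 (0.45 log units; beyond the scatter). For compound 4 the estimate is 35000 nM, with an expected range from 10000 nM to 100000 nM.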

Compound 4, half-maximal inhibitory concentration: > 100000 nM
Compound 4 was reported as a limit; the forecaster's own chance of this, stated with the estimate: 45%; middle value at least 2.8-fold (0.45 log units) from the limit.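

Adding the methoxy group at this aromatic carbon, ortho to a large group, meta to a methoxy group and para to a methoxy group, gives in this assay the first readable step of the set, an at least 6.0-fold higher number from compound 2 to compound 4 (0.78 log units; beyond the scatter), and it runs toward weaker inhibition. Compound 4 stands at a limit and not at a number, the same limit that compound 3 holds: the limit of > 100000 nM in this assay, at which 2 of the 4 values shown sit. The steps to compound 4 from compound 3 and from compound 1 cannot be read, as each has a limit at both ends.

On these data alone, how far the true value of compound 4 lies beyond its limit stays open, and with no true number for compound 3 or compound 1, the shift from compound 2 cannot be tied to this one position rather than to the full pattern of methoxy groups on the ring. Also open, as far as these compounds go, is what a different group on this aromatic carbon, such as an amine, a carboxylic acid or a longer chain, would do in this assay.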